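Bromo to chloro on compound 1

A few compounds are considered here, and "the series" means these few. Any claim that something is new, unique, unknown or untested is made for them only; others in the source may bear on it.

compound 1 `Nc1ccccc1NC(=O)c1ccc(CSc2ccc(Br)cc2)cc1` gives 4.35%
compound 2 `Nc1ccccc1NC(=O)c1ccc(CSc2ccc(C(F)(F)F)cn2)cc1` gives 4.3%
compound 3 `COC(=O)c1ccccc1SCc1ccc(C(=O)Nc2ccccc2N)cc1` gives 35.1%

In a functional assay on A-375 cells (Homo sapiens) for inhibition, read by CCK-8 assay, with a stated time of 72 h, tested at 2 uM (on this read-out higher numbers stand for more inhibition of growth at the one concentration tested and lower numbers for less inhibition of growth), compound 1 stands level with compound 2 within the scatter, and the gap up to compound 3 lies beyond the scatter. Compound 4 (`Nc1ccccc1NC(=O)c1ccc(CSc2ccc(Cl)cc2)cc1`) differs from compound 1 in one place (chloro in place of bromo on an aromatic carbon): chloro in place of bromo on an aromatic carbon, para to a large group. For the measured compounds named here, no measured pair here differs in just one place, so no direct precedent exists for this swap. No change beyond the scatter is expected, and the estimate for a number 2.7 percentage points higher from compound 1 to compound 4 (within the scatter) lies inside it. In this assay the estimate for compound 4 is 7% with an expected range (0% to 20%).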

Compound 4, percent growth inhibition at one concentration: 25.3%
Beside the measured number, compound 4's estimate is 18.3 percentage points below it, and the stated range ends below it.
By their numbers in this assay, from the lowest: compounds 2 and 1 (each within the scatter of the next); then compounds 4 and 3 (each within the scatter of the next).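

In this assay, chloro in place of bromo gives a number 21 percentage points higher from compound 1 to compound 4 (beyond the scatter) at this place on the ring, para to a large group. The earlier compounds shown here differ from one another in more than one place, so they could not show that exchanging this single atom can move the read-out beyond the scatter. Nothing measured here explains the step. The compounds shown leave open how fluoro, a methoxy group or an amine would read at this same place. They also leave open whether chloro in place of bromo would give a similar step on another compound.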